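Cytotoxicity notes: an aminophenyl swap on the shared core

The compounds below may be only part of what the source reports. "The series", "measured", "known", "first", "only" and "open" are said of these compounds alone.

Measured so far in an ADME assay on CEMx174 cells (Homo sapiens) for cytotoxicity; on this read-out higher numbers stand for lower toxicity in this test and lower numbers for higher toxicity in this test
- compound 1 (`CC1=C(C(=O)NCC2CCCCC2)C(c2cccc(O)c2)NC(=O)N1`) gives "not determined" (no result reported)
- compound 2 (`CCC1=C(C(=O)OCC2CCCCC2)C(c2cccc(N)c2)NC(=O)N1`) gives > 10000 nM

Only compound 2 has a reported reading, and compound 1 offers no result to compare with it. Compound 2 stands at > 10000 nM in this assay and this is a limit of the assay, not a number. Among the measured compounds shown here, no single number is therefore available anywhere in this small set, and no measured step exists to show how much a change on the shared core can move this read-out.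

The next compound to be tested is compound 3 (`CCC1=C(C(=O)OCC2CCCCC2)C(c2ccc(NC)cc2)NC(=O)N1`). The change from compound 2 is 4-(methylamino)phenyl in place of 3-aminophenyl on a saturated ring carbon, next to the ring nitrogen (4-(methylamino)phenyl in place of 3-aminophenyl on a saturated ring carbon). The cyclohexylmethyl ester and the ethyl group stay as they are.

The step that the limit leaves unreadable from compound 2 to compound 3 is expected to stay within the usual scatter, with neither direction favoured. This expectation rests on compound 2 alone, whose > 10000 nM is a limit, so another limit reading for compound 3 would not be surprising. For compound 3 the estimate is 20000 nM with an expected range (8000 nM to 60000 nM).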

Compound 3, half-maximal cytotoxic concentration: > 10000 nM
Compound 3 ended at the assay's limit (the forecaster's own chance of this, stated with the estimate: 70%); the middle value lies beyond the limit too.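

In this assay compound 3 gives > 10000 nM as a limit of the assay, not a number. No step can be read between compound 2 and compound 3, which share that limit: the limit of > 10000 nM in this assay, at which 2 of the 3 values shown sit. The compounds shown leave open how far 4-(methylamino)phenyl in place of 3-aminophenyl, or any other change on the shared core, moves this read-out.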